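N-Acetyl pyrazolines: furan-2-yl for 4-bromophenyl

The source may hold more compounds than are shown below. What is called first, only, known or untested is meant among the compounds shown, and "the series" means these compounds.

Measured so far:
compound 1 `COc1cc(C2CC(c3ccc(Br)cc3)=NN2C(C)=O)cc(OC)c1OC` gives 4530 nM
compound 2 `CC(=O)N1N=C(c2ccc(Br)cc2)CC1c1cccc(Cl)c1Cl` gives 50000 nM
compound 3 `COc1cc(C2CC(c3ccco3)=NN2C(C)=O)cc(OC)c1OC` gives 21300 nM

In a functional assay on HEp-2 cells (Homo sapiens) for cytotoxicity, read by sulforhodamine B assay, with a stated time of 48 h (on this read-out higher numbers stand for weaker inhibition and lower numbers for stronger inhibition), compound 2 gives the highest number of the three; the difference between the core of compound 2 and the core of compound 1 is not broken down here. The change furan-2-yl in place of 4-bromophenyl on a carbon with a double bond to nitrogen gave a 4.7-fold higher number from compound 1 to compound 3 (0.67 log units; beyond the scatter). The same kind of change, (furan-2-yl in place of 4-bromophenyl on a carbon with a double bond to nitrogen), leads to compound 4 `CC(=O)N1N=C(c2ccco2)CC1c1cccc(Cl)c1Cl`; around the place, the ring atom in compound 2 bears a group of 8 heavy atoms, whereas in compound 1 it bears a large group. Because the step of a 4.7-fold higher number from compound 1 to compound 3 (0.67 log units; beyond the scatter) pointed to weaker inhibition, a step in the same direction, a 2.0-fold higher number from compound 2 to compound 4 (0.30 log units; within the scatter), is expected, starting from the number that compound 2 gives, 50000 nM. For compound 4 the estimate in this assay is 100000 nM, between 40000 nM and 300000 nM.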

Compound 4, half-maximal inhibitory concentration: 43200 nM
Estimate against measurement, compound 4: 2.3-fold (0.36 log units) above; measured number inside the range.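

In this assay, furan-2-yl in place of 4-bromophenyl gives a 1.2-fold lower number from compound 2 to compound 4 (0.06 log units; within the scatter), and this step does not match the one seen on the core of compound 1: the same change on two cores in this assay, a 4.7-fold higher number (0.67 log units; beyond the scatter) from compound 1 to compound 3 and a 1.2-fold lower number (0.06 log units; within the scatter) from compound 2 to compound 4, 5.4-fold (0.74 log units) apart, beyond the scatter of two such steps

A step measured on one core therefore cannot be assumed to hold on the other in this series. These two pairs do not show which structural difference between the cores separates the steps, and they give no general rule for other cores.

Open, from the compounds shown here alone, is whether thiophen-2-yl, or a phenyl ring carrying a dimethylamino group, would follow the step on either core. Also open, going by these compounds, is whether a longer chain, such as propanoyl, in place of the acetyl group would alter the comparison.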